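Benzyl methylation on the sigma-1 amide series

The source may hold more compounds than are shown below. What is called first, only, known or untested is meant among the compounds shown, and "the series" means these compounds.

Measured compounds so far:
compound 1 `CC1CCN(CCCOc2ccc3c(c2)N(Cc2ccccc2)C(=O)CC3)CC1` — 1.1 nM
compound 2 `CN(C)CCCOc1ccc2c(c1)N(Cc1ccccc1)C(=O)CC2` — 83.2 nM
compound 3 `CCN(CC)CCCOc1ccc2c(c1)N(Cc1ccccc1)C(=O)CC2` — 39.4 nM

The three compounds share one core and differ only in the amine at the end of the three-bond chain that carries the aromatic oxygen. In an assay on cell membranes (strain Dunkin Hartley) for displacement of a labelled ligand from Sigma non-opioid intracellular receptor 1 (Cavia porcellus), read by scintillation counting, with a stated time of 180 min (on this read-out lower numbers stand for stronger inhibition and higher numbers for weaker inhibition), compound 1 gives the lowest number of the three. The measured steps are a 76-fold higher number from compound 1 to compound 2 (1.88 log units; beyond the scatter) and a 36-fold higher number from compound 1 to compound 3 (1.55 log units; beyond the scatter), both large, with the smaller step of a 2.1-fold lower number from compound 2 to compound 3 (0.32 log units; beyond the scatter) between the two open-chain amines.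

Compound 4 `Cc1ccc(CN2C(=O)CCc3ccc(OCCCN4CCC(C)CC4)cc32)cc1` keeps the 4-methylpiperidin-1-yl amine of compound 1 intact and changes instead the benzyl on the amide nitrogen: methyl in place of hydrogen on an aromatic carbon. For the measured compounds named here, none of the measured steps touches this part of the molecule; all three concern the amine and say nothing directly about the benzyl. Going by the values given here, the only guidance is that compound 1 already sits at the low end of the series and that the ring change is a single carbon added para to a large group, far from the amine that drove the measured steps. The expected step is therefore a 1.2-fold higher number from compound 1 to compound 4 (0.07 log units; within the scatter), within the scatter in either direction. Compound 4 is estimated at 1.3 nM in this assay, with a range from 0.5 nM to 3.5 nM.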

Compound 4, inhibition constant: 1.49 nM
Beside the measured number, compound 4's estimate is 1.1-fold (0.06 log units) below it; the measured number falls inside the stated range.
By their numbers in this assay, from the lowest: compounds 1 and 4 (each within the scatter of the next); then compound 3; then compound 2.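

In this assay, the benzyl on the amide nitrogen is the only part outside the amine that varies among the compounds shown, and going from benzyl to 4-methylbenzyl gives (  a 1.4-fold higher number from compound 1 to compound 4 (0.13 log units; within the scatter)  ), so the two compounds cannot be told apart on this read-out. With the 4-methylpiperidin-1-yl amine held constant, a methyl on this aromatic carbon, para to a large group, is therefore tolerated, whereas replacing that amine gave a far larger step (  a 76-fold higher number from compound 1 to compound 2 (1.88 log units; beyond the scatter)  ). Nothing available explains why this added methyl leaves the number within the scatter.

A single methyl is the only substituent shown on this ring, so it remains open whether a methoxy group, a chlorine atom or a trifluoromethyl group on the same carbon would also stay within the scatter of compound 1. From the compounds shown here alone, it is also open whether 4-methylbenzyl would behave the same way with the diethylamino amine of compound 3 (  39.4 nM  ) or the dimethylamino amine of compound 2 (  83.2 nM  ), since the benzyl change has been read only with the 4-methylpiperidin-1-yl amine.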